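The source may report more compounds than this note shows. Statements on the series, on what has been measured and on what is new or still open speak of the compounds shown alone.

Measured compounds:
Compound 1, `C/N=C(/NC#N)NCCCn1nc(-c2ccccc2)ccc1=O`: in a functional assay on the whole organism (stomach) with Rattus norvegicus as the target (a higher number here means that more compound is needed for the effect, a lower number that less compound is needed), compound 1 is reported only as a limit, > 100 mg/kg.
Compound 2, `CC/N=C(/NC#N)NCCCn1nc(-c2ccccc2)ccc1=O`: in this assay compound 2 gives 78.3 mg/kg.
Compound 3, `CCC/N=C(/NC#N)NCCCn1nc(-c2ccccc2)ccc1=O`: not yet measured.

Compound 2 holds the only actual number shown in this assay; the other entry is a limit, as the limit of > 100 mg/kg in this assay, at which 1 of the 2 values shown sits, records. Compound 3 differs from compound 2 by a single change: methyl in place of hydrogen on a saturated chain carbon, two bonds along the chain from a double-bonded nitrogen. Among the compounds with values here, only one measured step bears on it, the move an at least 1.2-fold lower number from compound 1 to compound 2 (0.10 log units; that floor lies within the scatter), which is the same kind of exchange, a methyl in place of hydrogen on a saturated chain carbon bound to a double-bonded nitrogen, and its known floor lies within the scatter. On that basis the step to compound 3 is expected to be small and may well fall within the scatter, with at most a modest lowering of the dose. The estimated step of a 1.3-fold lower number from compound 2 to compound 3 (0.12 log units; within the scatter) is therefore shallow. For compound 3 the expected value in this assay is 60 mg/kg, with a plausible range from 25 mg/kg to 150 mg/kg.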

Compound 3, dose for half-maximal effect: 100 mg/kg
Beside the measured number, compound 3's estimate is 1.7-fold (0.22 log units) below it; low and high end bracket the measured number.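

In this assay, extending the ethyl to the propyl gives a 1.3-fold higher number from compound 2 to compound 3 (0.11 log units; within the scatter), so at this position, on a saturated chain carbon two bonds along the chain from a double-bonded nitrogen, the added methyl produces no difference that can be told apart from ordinary repeat variation. The earlier exchange, a methyl in place of hydrogen on a saturated chain carbon bound to a double-bonded nitrogen, offered only a floor, an at least 1.2-fold lower number from compound 1 to compound 2 (0.10 log units; that floor lies within the scatter), whereas this step has a real number at both ends and gives the first readable size for lengthening this chain. The remaining comparison gives only a number no higher from compound 1 to compound 3 (the limit leaves the size open), and its size cannot be read: the limit of > 100 mg/kg in this assay, at which 1 of the 3 values shown sits.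

Going by these compounds, whether a longer chain such as butyl, or a branched group such as isopropyl, would shift the dose beyond the scatter remains open. On these data alone, it is equally open what a chain ending in an amine or a carboxylic acid would do at this end of the molecule.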